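Bromobenzyl amine variant of a diaryl ether series

This account rests on a few compounds, and the source may have more. Where it says the series, first, only, none or still open, it means among the compounds named here.

Two compounds of this set have been run in a functional assay on SW-620 cells (Homo sapiens) for inhibition, read by MTT assay, with a stated time of 72 h; a higher number here means a weaker inhibitor, a lower number a stronger inhibitor. Compound 2 `COc1ccc(CCCNCc2c(OC)cc(Oc3cccc(Nc4ccccc4)c3)cc2OC)cc1` gives 6400 nM; compound 1 `COc1cc(Oc2cccc(Nc3ccccc3)c2)cc(OC)c1CNCc1ccccc1` gives 7490 nM; the two numbers lie within the usual scatter of each other, as a 1.2-fold lower number from compound 1 to compound 2 (0.07 log units; within the scatter) states, so neither can be set apart from the other. Compound 3 `COc1cc(Oc2cccc(Nc3ccccc3)c2)cc(OC)c1CNCc1ccc(Br)cc1` is not yet measured. Relative to compound 2 it carries 4-bromophenyl in place of 2-(4-methoxyphenyl)ethyl on a saturated chain carbon bound to an amine nitrogen. For the measured compounds named here, the one measured step, from compound 1 to compound 2, concerns the same position and left the number unchanged beyond the scatter; compound 3 returns to a phenyl-sized group on that carbon, close to what compound 1 carries, with a bromine added. Going by the values given here, no measured step shows any effect of a halogen on this ring, so the expectation in this assay is no step beyond the scatter, a 1.1-fold higher number from compound 2 to compound 3 (0.04 log units; within the scatter), and compound 3 is estimated at 7000 nM, between 3000 nM and 16000 nM.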

Compound 3, half-maximal inhibitory concentration: 11200 nM
Compound 3: middle estimate off by 1.6-fold (0.20 log units), on the low side; the measured number falls inside the stated range.
By their numbers in this assay, from the lowest: compounds 2, 1 and 3 (each within the scatter of the next).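

Bromo in place of hydrogen on an aromatic carbon gives the first reading of a halogen on this ring in this assay, and a 1.5-fold higher number from compound 1 to compound 3 (0.17 log units; within the scatter) stays within the scatter. Shortening and changing the group on a saturated chain carbon bound to an amine nitrogen is equally unresolved, with a 1.8-fold higher number from compound 2 to compound 3 (0.24 log units; within the scatter) also within the scatter, so phenyl, 4-bromophenyl and 2-(4-methoxyphenyl)ethyl on that carbon cannot be set apart in these three compounds. No supporting data accompany these numbers to account for this flat picture.

Still open, on these data alone, is whether any group on that carbon moves the number beyond the scatter, for example a carboxylic acid on the ring or a morpholine in place of the aryl group. All three compounds share the same core, so they say nothing about how changes to the core would read in this assay at this level of activity.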